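The compounds below may be only part of what the source reports. "The series", "measured", "known", "first", "only" and "open" are said of these compounds alone.

In a functional assay on KG-1 cells (Homo sapiens) for cytotoxicity, read by luminescence and CellTiter-Glo, with a stated time of 3 days (on this read-out lower numbers stand for stronger inhibition and higher numbers for weaker inhibition), compound 1 `N#Cc1ccc(NC(=O)c2cc(-c3ccccc3)ccc2O)cc1` gives 1300 nM. Compound 3 `O=C(Nc1ccc(C(F)(F)F)cc1)c1cc(Br)ccc1O` gives 610 nM, a lower number, and the gap between the two lies beyond the scatter. For compound 2 `N#Cc1ccc(NC(=O)c2cc(Br)c3cccnc3c2O)cc1` the entry in this assay reads "not determined" (no result reported), so no number is in hand for it. Compound 4 `N#Cc1ccc(NC(=O)c2ccccc2O)cc1` differs from compound 1 by hydrogen in place of phenyl on an aromatic carbon. For the measured compounds named here, no step between two measured compounds tracks this change, so the expectation rests on compound 1 alone. The change is expected to raise the number by a moderate step, a 2.3-fold higher number from compound 1 to compound 4 (0.36 log units; beyond the scatter), though a result within the scatter of compound 1 is not excluded. Compound 4 is therefore estimated at 3000 nM in this assay, with a range from 1200 nM to 8000 nM.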

Compound 4, half-maximal inhibitory concentration: 5370 nM
Compound 4: middle estimate off by 1.8-fold (0.25 log units), on the low side; low and high end bracket the measured number.
By their numbers in this assay, from the lowest: compound 3; then compound 1; then compound 4.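

In this assay, for the compounds shown here, hydrogen in place of phenyl on this aromatic carbon, para to a hydroxy group, gives a 4.1-fold higher number from compound 1 to compound 4 (0.62 log units; beyond the scatter), the first step that isolates a single place. At this position, the phenyl group therefore goes with the lower number, and the change moves the read-out beyond the scatter. Nothing measured here accounts for the step. Going by these compounds, whether an amine, a methoxy group or a carboxylic acid on this carbon would keep the number of compound 1 remains open. A single step also leaves open whether the same change would behave alike with another group in place of the nitrile.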